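The source may report more compounds than this note shows. Statements on the series, on what has been measured and on what is new or still open speak of the compounds shown alone.

Three analogues on one shared core have numbers in a functional assay on PC-3 cells (Homo sapiens) for antiproliferative activity, read by MTT assay, with a stated time of 48 h (on this read-out lower numbers stand for stronger inhibition and higher numbers for weaker inhibition), so far. Compound 2 `NS(=O)(=O)c1ccc(Nc2ncc(F)c(Nc3nc4ccc(Cl)cc4s3)n2)cc1` gives 1430 nM and stands lowest of the three. Compound 1 `Cc1ccc2nc(Nc3nc(Nc4ccc(S(N)(=O)=O)cc4)ncc3F)sc2c1` gives 4960 nM in this assay and compound 3 `Cc1cnc(Nc2ccc(S(N)(=O)=O)cc2)nc1Nc1nc2ccc(Cl)cc2s1` gives 5400 nM there. Both steps out of compound 2 lie beyond the scatter: a 3.5-fold lower number from compound 1 to compound 2 (0.54 log units; beyond the scatter) with chloro in place of methyl on an aromatic carbon, and a 3.8-fold higher number from compound 2 to compound 3 (0.58 log units; beyond the scatter) with methyl in place of fluoro on an aromatic carbon. Compound 4 `COc1ccc2nc(Nc3nc(Nc4ccc(S(N)(=O)=O)cc4)ncc3F)sc2c1` awaits measurement in this assay and differs from compound 2 by methoxy in place of chloro on an aromatic carbon on the same aromatic carbon that distinguishes compound 1 from compound 2. Among the compounds with values here, the only step bearing on that position is a 3.5-fold lower number from compound 1 to compound 2 (0.54 log units; beyond the scatter) and it shows that chloro there gave the lower number; no measured compound carries methoxy at all. A modest rise from compound 2, likely short of the number of compound 1, is therefore expected. For compound 4 the expected step is a 2.1-fold higher number from compound 2 to compound 4 (0.32 log units; beyond the scatter) in this series. Compound 4 is estimated at 3000 nM with a range from 1200 nM to 8000 nM in round terms.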

Compound 4, half-maximal inhibitory concentration: > 50000 nM
Compound 4 ended at the assay's limit; the forecaster's own chance of this, stated with the estimate: 3%; middle value at least 16-fold (1.22 log units) from the limit.
By their numbers in this assay, from the lowest: compound 2; then compounds 1 and 3 (each within the scatter of the next). At a limit, above all of these: compound 4.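

In this assay compound 4 gives > 50000 nM, which is a limit of the assay and not a number: the limit of > 50000 nM in this assay, at which 1 of the 4 values shown sits. This position proves far more sensitive than the earlier exchange of methyl for chloro suggested, which amounted only to a 3.5-fold lower number from compound 1 to compound 2 (0.54 log units; beyond the scatter). Methoxy on this aromatic carbon gives an at least 34-fold higher number from compound 2 to compound 4 (1.54 log units; beyond the scatter) and an at least 10-fold higher number from compound 1 to compound 4 (1.00 log units; beyond the scatter), and both steps are bounds, so their full size cannot be read.

Going by these compounds, whether this step belongs to methoxy as a whole or to its oxygen alone stays open, and a hydroxyl, an ethoxy or an amine on the same carbon would help to separate the two. Also open, on these data alone, is whether the change of fluoro to methyl, seen as a 3.8-fold higher number from compound 2 to compound 3 (0.58 log units; beyond the scatter), would still register with methoxy in place of chloro.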